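The compounds below may be only part of what the source reports. "The series", "measured", "known", "first", "only" and "open" are said of these compounds alone.

Measured in a functional assay on MV4-11 cells (Homo sapiens) for antiproliferative activity, read by CCK-8 assay, with a stated time of 72 h; on this read-out lower numbers stand for stronger inhibition and higher numbers for weaker inhibition:
- compound 1 `Cn1cc(-c2ccccc2Oc2ccccc2)c2cc(C(=O)NCCCCCCC(=O)NO)[nH]c2c1=O`: 180 nM
- compound 2 `Cn1cc(-c2ccccc2Oc2ccccc2)c2cc(C(=O)NCc3ccc(C(=O)Nc4ccccc4N)cc3)[nH]c2c1=O`: 80 nM
- compound 3 `Cn1cc(-c2ccccc2Oc2ccccc2)c2cc(C(=O)NCc3ccc(C(=O)NO)cc3)[nH]c2c1=O`: 570 nM

Compound 3, at 570 nM, has the highest number of the three and is the weakest of them in this assay, with its steps to both others beyond the scatter.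

Compound 4 `Cn1cc(-c2ccccc2Oc2ccccc2)c2cc(C(=O)NCCCCC(=O)NO)[nH]c2c1=O` is not yet measured. It differs from compound 3 by 3-(hydroxycarbamoyl)propyl in place of 4-(hydroxycarbamoyl)phenyl on a saturated chain carbon bound to an amide-type nitrogen. The 4-(hydroxycarbamoyl)phenyl group therefore gives way to a 3-(hydroxycarbamoyl)propyl group with no ring, on a saturated chain carbon bound to an amide-type nitrogen.

The closest measured precedent is a 3.2-fold higher number from compound 1 to compound 3 (0.50 log units; beyond the scatter), a modest step between a chain and the same aromatic group. Read in reverse, it suggests a lower number for a chain. However, compound 1 carries 5-(hydroxycarbamoyl)pentyl rather than 3-(hydroxycarbamoyl)propyl, and no measured pair shows what chain length alone does. The other step, a 7.1-fold higher number from compound 2 to compound 3 (0.85 log units; beyond the scatter), concerns hydroxy and 2-aminophenyl on an amide-type nitrogen, which compound 4 leaves unchanged, so it offers no guide here.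

Only part of the precedent is expected to carry over, giving a small decrease that stays within the scatter. The estimated change is a 1.5-fold lower number from compound 3 to compound 4 (0.18 log units; within the scatter).

For compound 4 the expected value is 380 nM, with an estimated range of 150 nM to 1000 nM.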

Compound 4, half-maximal inhibitory concentration: 180 nM
The estimate for compound 4 lay 2.1-fold (0.32 log units) above the measured number; the measured number falls inside the stated range.
By their numbers in this assay, from the lowest: compound 2; then compounds 1 and 4 (each within the scatter of the next); then compound 3.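

In this assay, 3-(hydroxycarbamoyl)propyl in place of 4-(hydroxycarbamoyl)phenyl on a saturated chain carbon bound to an amide-type nitrogen gives a 3.2-fold lower number from compound 3 to compound 4 (0.50 log units; beyond the scatter), so the step seen earlier with 5-(hydroxycarbamoyl)pentyl also appears with a shorter chain. Chain length can now be read directly: 5-(hydroxycarbamoyl)pentyl and 3-(hydroxycarbamoyl)propyl show no change at the digits printed from compound 1 to compound 4 (within the scatter), and these two lengths are not separated in this read-out. Among compound 1, compound 3 and compound 4, all ending in hydroxycarbamoyl, the number therefore tracks the change from an open chain to the ring of 4-(hydroxycarbamoyl)phenyl and not the difference between these two chains.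

Nothing shown here gives a measured reason for either step. Still open, going by these compounds, are whether a chain shorter than 3-(hydroxycarbamoyl)propyl or longer than 5-(hydroxycarbamoyl)pentyl holds the number, and what a carboxylic acid in place of the hydroxycarbamoyl end would give on the same chain.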